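Urea variation on a quinolinyl-oxadiazole piperidine series

The compounds below may be only part of what the source reports. "The series", "measured", "known", "first", "only" and "open" are said of these compounds alone.

Measured so far:
compound 1 `O=C(NC1CCNCC1)N1CCC(c2nc(-c3ccc4ccccc4n3)no2)CC1` — 2500 nM
compound 2 `COc1ccccc1N(C)C(=O)N1CCC(c2nc(-c3ccc4ccccc4n3)no2)CC1` — 3100 nM

Going by the values given here, in a functional assay on Shh Light II cells (Mus musculus) for inhibition, read by a luciferase reporter (on this read-out higher numbers stand for weaker inhibition and lower numbers for stronger inhibition), compound 2 gives 3100 nM, the highest of the two numbers so far; its nearest neighbour is compound 1, with the step of a 1.2-fold higher number from compound 1 to compound 2 (0.09 log units; within the scatter) lying within the scatter. Compound 3 `O=C(Nc1cccnc1Cl)N1CCC(c2nc(-c3ccc4ccccc4n3)no2)CC1` is not yet measured. It differs from compound 2 at the urea: (2-chloropyridin-3-yl)amino in place of (2-methoxyphenyl)(methyl)amino on a carbonyl carbon. Among the compounds with values here, the only step at this position, a 1.2-fold higher number from compound 1 to compound 2 (0.09 log units; within the scatter), was within the scatter, so no step beyond the scatter is expected in a 1.1-fold lower number from compound 2 to compound 3 (0.04 log units; within the scatter). Compound 3 is therefore estimated at 2800 nM, with a range of 1000 nM to 8000 nM.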

Compound 3, half-maximal inhibitory concentration: 1600 nM
The estimate for compound 3 lay 1.8-fold (0.24 log units) above the measured number; the measured number falls inside the stated range.
By their numbers in this assay, from the lowest: compounds 3, 1 and 2 (each within the scatter of the next).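

In this assay a third, quite different urea substituent again leaves the read-out unmoved: a 1.9-fold lower number from compound 2 to compound 3 (0.29 log units; within the scatter), and a 1.6-fold lower number from compound 1 to compound 3 (0.19 log units; within the scatter). So (2-chloropyridin-3-yl)amino, (2-methoxyphenyl)(methyl)amino and (piperidin-4-yl)amino all lie within the scatter of one another on this carbonyl carbon, and these three groups do not separate. Nothing on hand explains this tolerance.

On these data alone, whether any group here can shift the number beyond the scatter stays open. A carboxylic acid, a longer alkyl chain or plain pyridin-3-yl without the chlorine would test this.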